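The source may hold more compounds than are shown below. What is called first, only, known or untested is meant among the compounds shown, and "the series" means these compounds.

Measured so far:
compound 1 `O=C(Nc1cc(C(F)(F)F)ccc1NC1CCCCC1)c1ccccc1` — "not active" (no number reported) in a functional assay on NALM-6 cells (Homo sapiens) for cytotoxicity, read by MTT assay, with a stated time of 48 h; a higher number here means a weaker inhibitor, a lower number a stronger inhibitor
compound 2 `O=C(Nc1cc(C(F)(F)F)ccc1NC1CCCCC1)c1ccncc1` — 59000 nM in this assay

Compound 1 carries no number in this assay; it is reported only as inactive, so it stands at the weak end with nothing to rank it against. Compound 2 at least gives a value, though a very high one. Compound 3 `O=C(Nc1cc(C(F)(F)F)ccc1N1CCCC1)c1ccccc1` is not yet measured; it differs from compound 1 by pyrrolidin-1-yl in place of cyclohexylamino on an aromatic carbon. Among the measured compounds shown here, no measured pair covers this change, so the expected step in this assay is uncertain and no direction is claimed beyond the scatter. Compound 3 is expected at 80000 nM, within 20000 nM to 300000 nM.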

Compound 3, half-maximal inhibitory concentration: "not active" (no number reported)
No number was reported for compound 3; no gap can be computed for the estimate.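

Compound 1 and compound 3 are both reported as inactive without a number, so no step can be read between them. No evidence at hand bears on this result. From the compounds shown here alone, how far replacing cyclohexylamino with pyrrolidin-1-yl shifts activity stays open.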